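Chlorophenyl to methoxyphenyl: expected cytotoxicity of compound 3

The compounds below may be only part of what the source reports. "The series", "measured", "known", "first", "only" and "open" are said of these compounds alone.

Measured compounds:
compound 1, `N#Cc1ccc(Nc2nccc(OCc3cccc(Cl)c3)n2)cc1`, 153000 nM
compound 2, `N#Cc1ccc(Nc2nccc(OCc3ccc(Cl)cc3)n2)cc1`, 156000 nM

In an ADME assay on MT4 cells (Homo sapiens) for cytotoxicity, read by MTT assay, with a stated time of 5 days (a higher number here means that more compound is tolerated, a lower number that less compound is tolerated), compound 2 holds the higher of the two numbers, but its nearest neighbour is compound 1 and the step of a 1.0-fold higher number from compound 1 to compound 2 (0.01 log units; within the scatter) is within the scatter. Compound 3, `COc1cccc(COc2ccnc(Nc3ccc(C#N)cc3)n2)c1`, carries the change (3-methoxyphenyl in place of 4-chlorophenyl on a saturated chain carbon bound to an oxygen on an aromatic ring). Within the data shown here, the single measured step, a 1.0-fold higher number from compound 1 to compound 2 (0.01 log units; within the scatter), concerns a chlorophenyl only; no measured pair exchanges chlorine for methoxy, so the data give no direction. Compound 3 is therefore expected to sit close to compound 2, a step of a 1.0-fold lower number from compound 2 to compound 3 (0.02 log units; within the scatter), estimated at 150000 nM with a range of 60000 nM to 350000 nM.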

Compound 3, half-maximal cytotoxic concentration: 118000 nM
The estimate for compound 3 lay 1.3-fold (0.10 log units) above the measured number; the measured number falls inside the stated range.
By their numbers in this assay, from the lowest: compounds 3, 1 and 2 (each within the scatter of the next).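

In this assay, the comparison at this position now extends from where a chlorine sits to which group is present: 3-methoxyphenyl in place of 4-chlorophenyl gives a 1.3-fold lower number from compound 2 to compound 3 (0.12 log units; within the scatter), and methoxy in place of chloro on an aromatic carbon gives a 1.3-fold lower number from compound 1 to compound 3 (0.11 log units; within the scatter). Both steps lie within the scatter, so the readings do not separate methoxy from chloro here. No measured evidence bears on this result. On these data alone, whether an amine or a carboxylic acid on the aromatic ring, or a longer chain on the oxygen, would give a step beyond the scatter remains open.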